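Phenylsulfanyl in Place of 4-Methoxybenzyl: A Binding Estimate

A few compounds are considered here, and "the series" means these few. Any claim that something is new, unique, unknown or untested is made for them only; others in the source may bear on it.

Compound 1 `OC(COc1cccc2ccccc12)CN1CCC(Cc2ccc(F)cc2)CC1`: 32 nM
Compound 2 `COc1ccc(CC2CCN(CC(O)COc3cccc4ccccc34)CC2)cc1`: 74 nM

Of the compounds shown here, two have been measured in an assay on CHO-K1 cells for binding affinity to D(4) dopamine receptor (Homo sapiens); on this read-out lower numbers stand for stronger inhibition and higher numbers for weaker inhibition. Compound 1 gives 32 nM, and compound 2 gives 74 nM, the higher of the two numbers. Within the data shown here, the single measured step, a 2.3-fold higher number from compound 1 to compound 2 (0.36 log units; beyond the scatter), is a modest weakening brought by a methoxy in place of fluoro on an aromatic carbon.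

Compound 3 `OC(COc1cccc2ccccc12)CN1CCC(Sc2ccccc2)CC1` has not been measured. It differs from compound 2 by phenylsulfanyl in place of 4-methoxybenzyl on a saturated ring carbon, a phenylsulfanyl in place of 4-methoxybenzyl on a saturated ring carbon. Among the measured compounds shown here, no measured step touches this saturated ring carbon; the only available step concerns another part of the shared core and was modest. With nothing that argues for a large shift in either direction, compound 3 is expected to show only a small step, a 1.1-fold lower number from compound 2 to compound 3 (0.02 log units; within the scatter). The estimate for compound 3 in this assay is 70 nM, within a range of 15 nM to 300 nM.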

Compound 3, inhibition constant: 32 nM
For compound 3 the middle estimate is 2.2-fold (0.34 log units) above the measured one; low and high end bracket the measured number.
By their numbers in this assay, from the lowest: compounds 1 and 3 (each within the scatter of the next); then compound 2.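

The group on the saturated ring carbon can be exchanged without loss in this assay: phenylsulfanyl in place of 4-methoxybenzyl gives a 2.3-fold lower number from compound 2 to compound 3 (0.36 log units; beyond the scatter), so this change at the position recovers a step of about the same size as the one lost on the aromatic ring. Set against the 4-fluorobenzyl group of compound 1, phenylsulfanyl gives no change at the digits printed from compound 1 to compound 3 (within the scatter), which shows that a phenyl ring attached through sulfur serves as well here as the fluorinated benzyl group. Nothing available explains why these groups compare as they do.

Compound 3 differs from compound 2 in both the sulfur link and the absent methoxy, and the compounds shown do not separate those two changes. As far as these compounds go, how an amine, a carboxylic acid or a longer chain at this ring carbon would behave in this assay also remains open.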